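From a Phenethyl Arm to a tert-Butylphenyl Arm

A few compounds are considered here, and "the series" means these few. Any claim that something is new, unique, unknown or untested is made for them only; others in the source may bear on it.

Measured so far:
Compound 1, `COc1ccccc1Oc1ccc2c(NCCCNCc3ccco3)ccnc2c1`: 6500 nM
Compound 2, `FC(F)(F)c1ccc(-c2ccc3c(NCCCNCc4ccco4)ccnc3c2)cc1`: 3470 nM
Compound 3, `c1ccc(CCc2ccc3c(NCCCNCc4ccco4)ccnc3c2)cc1`: 16000 nM

All three values come from an ADME assay on HepG2 cells (Homo sapiens) for cytotoxicity, read by luminescence, CellTiter-Glo and ATP content, with a stated time of 72 h; a lower number here means that less compound is needed, a higher number that more compound is needed for the effect. The compounds share one core and differ only in the group attached at one aromatic carbon of it. Compound 3 stands highest of the three: the step of a 2.5-fold higher number from compound 1 to compound 3 (0.39 log units; beyond the scatter) and the step of a 4.6-fold higher number from compound 2 to compound 3 (0.66 log units; beyond the scatter) both lie beyond the scatter, so more of compound 3 is needed than of either other compound. Compound 1 and compound 2 cannot be ordered, as a 1.9-fold lower number from compound 1 to compound 2 (0.27 log units; within the scatter) lies within the scatter.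

Compound 4, `CC(C)(C)c1ccc(-c2ccc3c(NCCCNCc4ccco4)ccnc3c2)cc1`, has not yet been measured. Its change from compound 3 is 4-(tert-butyl)phenyl in place of phenethyl on an aromatic carbon. The step that bears on this is a 4.6-fold higher number from compound 2 to compound 3 (0.66 log units; beyond the scatter), in which a directly attached phenyl carrying trifluoromethyl gave way to phenethyl; compound 4 returns to a directly attached phenyl, now carrying tert-butyl. A lower number is therefore expected for compound 4, of about a 3.6-fold lower number from compound 3 to compound 4 (0.55 log units; beyond the scatter). Compound 4 is estimated at 4500 nM, with a likely range from 1500 nM to 13000 nM.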

Compound 4, half-maximal effective concentration: 3150 nM
Beside the measured number, compound 4's estimate is 1.4-fold (0.15 log units) above it, and the stated range covers the measured number.
By their numbers in this assay, from the lowest: compounds 4, 2 and 1 (each within the scatter of the next, the first and the last beyond it); then compound 3.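

In this assay the change from phenethyl to 4-(tert-butyl)phenyl gives a 5.1-fold lower number from compound 3 to compound 4 (0.71 log units; beyond the scatter) and so shows, with a second phenyl-bearing compound, that compound 3 is the one that stands apart at this aromatic carbon. Changing only the group on that phenyl, from trifluoromethyl to tert-butyl, gives a 1.1-fold lower number from compound 2 to compound 4 (0.04 log units; within the scatter) and leaves the two compounds indistinguishable, so this assay does not separate these two groups here. Compound 4 does separate from compound 1, with a 2.1-fold lower number from compound 1 to compound 4 (0.31 log units; beyond the scatter) as a modest step, even though compound 2 could not be ordered against compound 1.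

Open, as far as these compounds go, is whether a phenyl carrying an amine or a carboxylic acid in place of tert-butyl would stay level with compound 2 and compound 4 or move toward compound 3. No measurement shown here explains why these groups fall in this order.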